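The source may hold more compounds than are shown below. What is called first, only, known or untested is meant among the compounds shown, and "the series" means these compounds.

Compound 1 `CC1(C)CC(NC(=S)Nc2cccc(C#N)c2)c2cc(Cl)ccc2O1` was tested in a functional assay on T98G cells (Homo sapiens) for inhibition, read by MTT assay, with a stated time of 72 h (a higher number here means a weaker inhibitor, a lower number a stronger inhibitor), where compound 1 gives 10000 nM. Compound 2 `CC1(C)CC(NC(=O)Nc2ccccc2Cl)c2cc(Br)ccc2O1` has also been measured: in this assay compound 2 gives 11000 nM, a number that sits within the usual scatter of the value for compound 1, so the two are indistinguishable on these data. Compound 3 `CC1(C)CC(NC(=S)Nc2cccc(C#N)c2)c2cc(F)ccc2O1` is not yet measured. It differs from compound 1 in one place: fluoro in place of chloro on an aromatic carbon. Among the compounds with values here, no measured pair shows the effect of such an exchange here. The step from compound 1 to compound 3 is expected to be small, a 1.2-fold higher number from compound 1 to compound 3 (0.08 log units; within the scatter), not clearly beyond the scatter. For compound 3 a value of 12000 nM is estimated, within a range from 5000 nM to 30000 nM.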

Compound 3, half-maximal inhibitory concentration: 39000 nM
Compound 3: middle estimate off by 3.3-fold (0.51 log units), on the low side; measured number above the stated range.
By their numbers in this assay, from the lowest: compounds 1 and 2 (each within the scatter of the next); then compound 3.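

In this assay this position on the aromatic ring is not indifferent to which halogen it carries: fluoro in place of chloro gives a 3.9-fold higher number from compound 1 to compound 3 (0.59 log units; beyond the scatter) and so a weaker inhibitor, a modest change but a real one for a swap of a single atom. Nothing available explains this step. As far as these compounds go, whether a methoxy group or an amine at the same position would match chloro remains open. Within the data shown here, only this one pair shows the exchange, so its size with other groups elsewhere on the molecule is also unknown.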